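Five-membered heteroaryl amines: tolerated concentration in canine kidney cells

A few compounds are considered here, and "the series" means these few. Any claim that something is new, unique, unknown or untested is made for them only; others in the source may bear on it.

Compound 1 `C[C@H]1[C@H](NCc2cncs2)C[C@H]2C[C@@H]1C2(C)C`: in an ADME assay on MDCK cells (Canis lupus familiaris) for cytotoxicity, read by microscopy, with a stated time of 48 h (a higher number here means that more compound is tolerated, a lower number that less compound is tolerated), compound 1 gives > 100000 nM, which is a limit of the assay.
Compound 2 `C[C@H]1[C@H](NCc2cnccn2)C[C@H]2C[C@@H]1C2(C)C`: in this assay compound 2 gives > 100000 nM, again a limit of the assay.
Compound 3 `C[C@H]1[C@H](NCc2cccs2)C[C@H]2C[C@@H]1C2(C)C`: in this assay compound 3 gives 25000 nM.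

For the measured compounds named here, compound 3 holds the only actual number in the set; the other two values sit at the limit of > 100000 nM in this assay, at which 2 of the 3 values shown sit. Two measured steps lead to compound 3 from the limit compounds: an at least 4.0-fold lower number from compound 1 to compound 3 (0.60 log units; beyond the scatter) and an at least 4.0-fold lower number from compound 2 to compound 3 (0.60 log units; beyond the scatter). Both read the same way, with thiophen-2-yl giving a lower tolerated concentration than either 1,3-thiazol-5-yl or pyrazin-2-yl.

Compound 4 `C[C@H]1[C@H](NCc2ccoc2)C[C@H]2C[C@@H]1C2(C)C` differs from compound 3 as follows: furan-3-yl in place of thiophen-2-yl on a saturated chain carbon bound to an amine nitrogen. Going by the values given here, no measured step exchanges one five-membered ring with a single hetero atom for another, so neither of the two measured steps bears directly on this change; they only show where thiophen-2-yl stands against the two-hetero-atom rings. With that in mind, compound 4 is expected to fall between the number of compound 3 and the limit, an expected step of a 2.0-fold higher number from compound 3 to compound 4 (0.30 log units; within the scatter). The estimate for compound 4 in this assay is 50000 nM, with an expected range from 20000 nM to 100000 nM.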

Compound 4, minimum cytotoxic concentration: > 100000 nM
Compound 4 was reported as a limit (the forecaster's own chance of this, stated with the estimate: 40%); middle value at least 2.0-fold (0.30 log units) from the limit.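

For the compounds shown here, at this place, on a saturated chain carbon bound to an amine nitrogen, furan-3-yl in place of thiophen-2-yl gives the first exchange between two five-membered rings with 1 hetero atom in this assay: an at least 4.0-fold higher number from compound 3 to compound 4 (0.60 log units; beyond the scatter). The lower tolerated concentration therefore does not extend to every ring of this kind, and among the compounds shown only compound 3, with thiophen-2-yl, has it. Compound 1, compound 2 and compound 4 all carry limits of the assay, so the steps among them cannot be read: the limit of > 100000 nM in this assay, at which 3 of the 4 values shown sit.

This step changes both the hetero atom and the ring attachment, and the compounds shown do not separate the two. Thiophen-3-yl and furan-2-yl on the same carbon would separate them, while phenyl would test whether a ring hetero atom matters at all.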